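Methylsulfonyl for phenylsulfanyl on a quinolinone amide core

The compounds below may be only part of what the source reports. "The series", "measured", "known", "first", "only" and "open" are said of these compounds alone.

Measured so far:
compound 1, `CN(C(=O)c1c(O)c2cc(Sc3ccccc3)ccc2n(C)c1=O)c1ccccc1`: 100%
compound 2, `CCn1c(=O)c(C(=O)N(C)c2ccccc2)c(O)c2cc(SC)ccc21`: 83%

Two compounds of the series carry a reading in a functional assay on the whole organism for inhibition, with Mus musculus as the target, at a dose of 32 mg/kg by the oral route; on this read-out lower numbers stand for less inhibition and higher numbers for more inhibition at the one dose given (going by the name of the read-out). Compound 1 stands highest of the two; in this assay compound 1 gives 100%. Compound 2 gives 83%, a gap beyond the scatter, and as the two structures differ in more than one place nothing is drawn from the pair beyond the two numbers.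

Compound 3, `CN(C(=O)c1c(O)c2cc(S(C)(=O)=O)ccc2n(C)c1=O)c1ccccc1`, is not yet measured. It differs from compound 1 in one place: methylsulfonyl in place of phenylsulfanyl on an aromatic carbon

For the measured compounds named here, no single-point step between measured compounds exists, so the size of the change is judged from the structures alone. The expected step from compound 1 to compound 3 is a number 35 percentage points lower from compound 1 to compound 3 (beyond the scatter), a fall beyond the scatter, because the reading of compound 1 is 100% and cannot rise further. Compound 3 is estimated at 65%, with a range from 30% to 100%.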

Compound 3, a percentage reported as inhibition, in the whole organism at one dose (the size of the read-out at that dose, not a potency): 0%
Compound 3: middle estimate off by 65 percentage points, on the high side; measured number outside the range, below it.
By their numbers in this assay, from the lowest: compound 3; then compound 2; then compound 1.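

In this assay, for the compounds shown here, the change to methylsulfonyl in place of phenylsulfanyl on an aromatic carbon gives a number 100 percentage points lower from compound 1 to compound 3 (beyond the scatter), the first step that can be read at a single place. With the rest of the structure held constant, the reading therefore depends heavily on the group at this position, and phenylsulfanyl cannot be exchanged for methylsulfonyl here without losing the whole effect at this dose, something the earlier pair, which differs in more than one place, could not show. Nothing shown accounts for the size of this step.

This single swap changes both the ring and the sulfur group, so the two contributions remain unseparated. Phenylsulfonyl at this position would separate them, while an amine or a longer alkyl chain would show how broadly the position accepts other groups.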